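The compounds below may be only part of what the source reports. "The series", "measured", "known", "first", "only" and "open" are said of these compounds alone.

Compound 1 `O=C1c2ccc(Cl)cc2CN1c1cccnc1` — 12.8 mL/min/kg
Compound 2 `CCC1c2cc(Cl)ccc2C(=O)N1c1cccnc1` — 6.6 mL/min/kg
Compound 3 `CCC(=O)N[C@@H]1CCCc2c1cncc2N1Cc2cc(Cl)ccc2C1=O` — < 3.5 mL/min/kg

In an ADME assay on microsomes from liver (Homo sapiens) for metabolic stability, read by LC-MS, using NADPH, with stated times of 10 min and 30 min (a higher number here means faster removal of the compound, a lower number slower removal), compound 1 gives 12.8 mL/min/kg and compound 2 gives 6.6 mL/min/kg. The change between them, (ethyl in place of hydrogen on a saturated ring carbon), made a 1.9-fold lower number from compound 1 to compound 2 (0.29 log units; within the scatter). For compound 3 in this assay the result is a limit of the assay, < 3.5 mL/min/kg (the limit of < 3.5 mL/min/kg in this assay, at which 1 of the 3 values shown sits). The difference between the core of compound 1 and the core of compound 3 is not broken down here.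

Compound 4 `CCC(=O)N[C@@H]1CCCc2c1cncc2N1C(=O)c2ccc(Cl)cc2[C@H]1CC` is yet to be measured in this assay. It differs from compound 3 by ethyl in place of hydrogen on a saturated ring carbon. The places differ in their wording: in compound 1 the neighbouring ring atom bears a pyridin-3-yl group, in compound 3 a large group, so this is the same kind of change rather than the same one.

In this assay compound 4 is expected to give 2.5 mL/min/kg, between 1 mL/min/kg and 5 mL/min/kg, most likely reported again only as a limit. That expectation means a step that the limit leaves unreadable from compound 3 to compound 4. It rests on the earlier step of a 1.9-fold lower number from compound 1 to compound 2 (0.29 log units; within the scatter), which lay within the scatter. It also rests on compound 3 already standing at the limit < 3.5 mL/min/kg.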

Compound 4, clearance: < 3.5 mL/min/kg
Compound 4: only a limit was reported; the forecaster's own chance of this, stated with the estimate: 70%; the middle value is on the limit's open side.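

In this assay compound 4 gives < 3.5 mL/min/kg, a limit of the assay. Compound 3 stands at the same limit, and no step can be read between compound 3 and compound 4. The compounds shown leave open whether ethyl in place of hydrogen on a saturated ring carbon changes clearance at all in this pair.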